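Chloro for fluoro: one exchange in the series

The source may hold more compounds than are shown below. What is called first, only, known or untested is meant among the compounds shown, and "the series" means these compounds.

Measured so far:
compound 1 `N=C(N)c1ccc(-c2ccc(-c3cncc4ccccc34)s2)s1`, 1580 nM
compound 2 `N=C(N)c1ccc(-c2ccc(-c3ccc(F)cc3)o2)o1`, 2320 nM

In a functional assay on SK-OV-3 cells (Homo sapiens) for inhibition, read by sulforhodamine B assay, with a stated time of 48 h (a higher number here means a weaker inhibitor of growth, a lower number a stronger inhibitor of growth), compound 2 gives 2320 nM, the higher of the two numbers; compound 1 gives 1580 nM, and the gap between the two lies within the scatter, so no order between them is claimed. Compound 3 `N=C(N)c1ccc(-c2ccc(-c3ccc(Cl)cc3)o2)o1` differs from compound 2 by chloro in place of fluoro on an aromatic carbon. Among the compounds with values here, no measured pair shows such an exchange, so nothing in hand sizes it; the step expected a 1.2-fold lower number from compound 2 to compound 3 (0.06 log units; within the scatter) is none beyond the scatter. Compound 3 is therefore estimated at 2000 nM, with a range from 900 nM to 4500 nM.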

Compound 3, concentration for 50% growth inhibition: 1790 nM
Compound 3: the middle estimate sits 1.1-fold (0.05 log units) above what was measured, and the stated range covers the measured number.
By their numbers in this assay, from the lowest: compounds 1, 3 and 2 (each within the scatter of the next).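

The exchange of chloro for fluoro, para to a large group, gives a 1.3-fold lower number from compound 2 to compound 3 (0.11 log units; within the scatter) in this assay. This first matched pair shows that the two halogens cannot be told apart at this position in this assay. Nothing at hand bears on the reason for this result.

From the compounds shown here alone, whether a methoxy group, an amine or a carboxylic acid on the same aromatic carbon would move the number beyond the scatter remains open. So does the outcome of removing the halogen altogether, leaving hydrogen at this position.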